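The source may hold more compounds than are shown below. What is called first, only, known or untested is meant among the compounds shown, and "the series" means these compounds.

Of the compounds shown here, two from this series have been tested in a toxicity assay on HepG2 2.2.15 cells (Homo sapiens) for cytotoxicity, read by CellTiter-Glo; a higher number here means that more compound is tolerated, a lower number that less compound is tolerated. Compound 1, with the structure `O=C1CC(c2cnc(C(F)(F)F)s2)CN1c1cnn2c1CN(C(=O)Nc1cc(F)c(F)c(F)c1)C(C1CC1)C2`, stands highest of the two numbers: in this assay compound 1 gives 38500 nM. The nearest comparison is compound 2, with the structure `O=C1OC(c2ccc(F)cc2)CN1c1cnn2c1CN(C(=O)Nc1cc(F)c(F)c(F)c1)C(C1CC1)C2`, which in this assay gives 3560 nM; that gap lies beyond the usual scatter, but the two compounds differ in more than one place, so the pair alone does not tell which part of the change matters.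

Compound 3, with the structure `O=C1CC(c2ncco2)CN1c1cnn2c1CN(C(=O)Nc1cc(F)c(F)c(F)c1)C(C1CC1)C2`, has not yet been measured. It is compound 1 with one part exchanged: 1,3-oxazol-2-yl in place of 2-(trifluoromethyl)-1,3-thiazol-5-yl on a saturated ring carbon. For the measured compounds named here, no measured pair in this set isolates such a swap, so there is no direct precedent to lean on. The shared core, the urea and the cyclopropyl group are untouched, and only the aromatic ring on the saturated ring carbon changes. The step from compound 1 to compound 3 in this assay is therefore expected to be small, a 1.2-fold higher number from compound 1 to compound 3 (0.07 log units; within the scatter), with a slight lean toward a higher number rather than a lower one. For compound 3 in this assay the expected value is 45000 nM, within a range from 15000 nM to 100000 nM.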

Compound 3, half-maximal cytotoxic concentration: > 200000 nM
Compound 3 was reported as a limit; the forecaster's own chance of this, stated with the estimate: 25%; middle value at least 4.4-fold (0.64 log units) away from the limit.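

For the compounds shown here, this is the only step in the set that changes a single place, and in this assay it reads an at least 5.1-fold higher number from compound 1 to compound 3 (0.71 log units; beyond the scatter), so the group on the saturated ring carbon can alone move this number beyond the scatter while the rest of compound 1 stays untouched. Going by these compounds, compound 3 reads > 200000 nM, which is a limit of the assay and not a number, so the step gives only a minimum and its full size stays unknown: the limit of > 200000 nM in this assay, at which 1 of the 3 values shown sits. Both groups are five-membered aromatic rings with 2 hetero atoms, so an exchange within this one ring type is enough to shift the result.

The exchange still alters several things at once, since the trifluoromethyl group leaves, oxygen replaces sulfur in the ring and the ring is attached through a different position, and the compounds shown cannot separate these parts. A plain 1,3-thiazol-5-yl group at the same carbon would test the trifluoromethyl group on its own, while an amine or a carboxylic acid there would show how far the number responds to groups outside this ring type.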